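Cyclohexyl in place of 3-fluorophenyl: outlook for compound 4

The source may hold more compounds than are shown below. What is called first, only, known or untested is meant among the compounds shown, and "the series" means these compounds.

Compound 1 `O=C(CN1CCN(c2ccc(F)cc2)CC1)Nc1nc2c(s1)CCCCC2` and compound 3 `Cc1nc(NC(=O)CN2CCN(c3ccc(F)cc3)CC2)sc1C` share the 4-fluorophenyl group and differ in the core alone. In an assay on isolated protein for inhibition of long-chain fatty acid transport protein 1 (Mus musculus), read by scintillation counting, with a stated time of 20 min (on this read-out lower numbers stand for stronger inhibition and higher numbers for weaker inhibition), compound 1 gives 2000 nM and compound 3 gives 1700 nM, two values that lie within the usual scatter of each other. Compound 2 `O=C(CN1CCN(c2cccc(F)c2)CC1)Nc1nc2c(s1)CCCC2` carries the 3-fluorophenyl instead. In this assay, within the data shown here, compound 2 reaches only the limit of > 10000 nM; it is the one value sitting at the limit of > 10000 nM in this assay, at which 1 of the 3 values shown sits. Compound 4 `O=C(CN1CCN(C2CCCCC2)CC1)Nc1nc2c(s1)CCCC2` is the untested partner: cyclohexyl in place of 3-fluorophenyl on an amine nitrogen in a ring. Among the measured compounds shown here, no measured step sets the size of this change, since compound 2 gives only a limit. The step of a number no higher from compound 2 to compound 4 (the limit leaves the size open) is expected to stay near the limit, with no clear gain. Compound 4 is estimated at 10000 nM, between 3000 nM and 30000 nM, and may again return only a limit.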

Compound 4, half-maximal inhibitory concentration: > 10000 nM
Compound 4: a limit, no number; the forecaster's own chance of this, stated with the estimate: 55%; the middle value lies on the limit itself.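

Compound 2 and compound 4 each return only a limit, and the step between them cannot be read. The compounds shown leave open whether cyclohexyl or 3-fluorophenyl on the ring amine nitrogen gives stronger inhibition.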